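Ring size on the chain: from compound 3 to compound 4

The source may hold more compounds than are shown below. What is called first, only, known or untested is meant among the compounds shown, and "the series" means these compounds.

Measured compounds, each in an assay on cell membranes for displacement of a labelled ligand from Sigma non-opioid intracellular receptor 1 (Rattus norvegicus); on this read-out lower numbers stand for stronger inhibition and higher numbers for weaker inhibition: compound 1 `CCCc1ccc2c(c1)sc(=O)n2CCN1CCCCCC1` gives 1.6 nM; compound 2 `O=c1sc2ccccc2n1CCCCCCN1CCCCCC1` gives 7.5 nM; compound 3 `CCC(=O)c1ccc2c(c1)sc(=O)n2CCN1CCCCCC1` gives 4.5 nM.

Compound 3 stands second highest of the three numbers. Among the compounds with values here, its nearest neighbour is compound 2, within the scatter; the furthest is compound 1, beyond it, and the single one-place step, a 2.8-fold higher number from compound 1 to compound 3 (0.45 log units; beyond the scatter), is modest.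

Compound 4 `CCC(=O)c1ccc2c(c1)sc(=O)n2CCN1CCCC1` differs from compound 3 by pyrrolidin-1-yl in place of azepan-1-yl on a saturated chain carbon, two bonds along the chain from an aromatic nitrogen. Within the data shown here, none of the measured steps alters the ring at the end of the chain, so no measured step bears directly on this change; the data give no guide to its size or direction. Compound 4 is therefore expected near compound 3, with a slightly higher number, a 2.7-fold higher number from compound 3 to compound 4 (0.43 log units; beyond the scatter), estimated at 12 nM within 3 nM to 50 nM.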

Compound 4, inhibition constant: 116 nM
For compound 4 the middle estimate is 9.7-fold (0.99 log units) below the measured one; the whole stated range lies below it.
By their numbers in this assay, from the lowest: compound 1; then compounds 3 and 2 (each within the scatter of the next); then compound 4.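

In this assay the ring at the end of the chain proves a sensitive place: pyrrolidin-1-yl in place of azepan-1-yl gives a 26-fold higher number from compound 3 to compound 4 (1.41 log units; beyond the scatter). Within the data shown here, this is the first measured change at this position, and it shows that the smaller ring is poorly tolerated with the propanoyl group on the shared core. No supporting measurement accounts for the size of this step.

From the compounds shown here alone, what piperidin-1-yl or morpholin-4-yl would give on the same chain remains open. So does whether the step would hold with propyl in place of propanoyl.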